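Adding a Hydroxy Group to the Linker Chain

The compounds below may be only part of what the source reports. "The series", "measured", "known", "first", "only" and "open" are said of these compounds alone.

Three compounds have been measured in an assay on HEK293 cells for displacement of a labelled ligand from 5-hydroxytryptamine receptor 7 (Homo sapiens), read by scintillation counting, with a stated time of 1 h; a lower number here means a stronger inhibitor, a higher number a weaker inhibitor:

Compound 1, `CC(C)c1ccccc1OCCCN1CCC(NS(=O)(=O)c2ccc(F)cc2)CC1`, gives 32 nM.
Compound 2, `O=S(=O)(NC1CCN(CCCOc2ccccc2-c2ccccc2)CC1)c1cccc(Cl)c1`, gives 52 nM.
Compound 3, `CC(C)c1ccccc1OCC(O)CN1CCC(NS(=O)(=O)c2ccc(F)cc2)CC1`, gives 104 nM.

Compound 1 and compound 2 carry different cores, and the difference between the two cores is not broken down here; their values in this assay lie within the usual scatter of each other, as do those of compound 2 and compound 3. Compound 3 arises from compound 1 by hydroxy in place of hydrogen on a saturated chain carbon bound to two saturated chain carbons, and this change brought a 3.3-fold higher number from compound 1 to compound 3 (0.51 log units; beyond the scatter). Compound 4, `O=S(=O)(NC1CCN(CC(O)COc2ccccc2-c2ccccc2)CC1)c1cccc(Cl)c1`, is not yet measured; it arises from compound 2 by hydroxy in place of hydrogen on a saturated chain carbon bound to two saturated chain carbons, the same change at the same kind of place, occurring twice among these compounds. Because a 3.3-fold higher number from compound 1 to compound 3 (0.51 log units; beyond the scatter) went in one clear direction, a step of similar size, a 3.1-fold higher number from compound 2 to compound 4 (0.49 log units; beyond the scatter), is expected for compound 4. Compound 4 is therefore estimated at 160 nM in this assay, expected to lie between 70 nM and 400 nM.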

Compound 4, inhibition constant: 33 nM
Compound 4: middle estimate off by 4.8-fold (0.69 log units), on the high side, outside the stated range (below it).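

In this assay, putting hydroxy in place of hydrogen on a saturated chain carbon bound to two saturated chain carbons gave a 1.6-fold lower number from compound 2 to compound 4 (0.20 log units; within the scatter), so on this core the change left the number within the scatter. The two cores did not respond alike to the same change: the same change on two cores in this assay, a 3.3-fold higher number (0.51 log units; beyond the scatter) from compound 1 to compound 3 and a 1.6-fold lower number (0.20 log units; within the scatter) from compound 2 to compound 4, 5.1-fold (0.71 log units) apart, beyond the scatter of two such steps This shows that the rise in the number seen on the core of compound 1 did not carry over to the core of compound 2, but it does not show which difference between the two cores sets the steps apart.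

The compounds shown leave open how the same change would run on a third core. They also leave open whether an amine or a methoxy group at that chain carbon would follow the hydroxy on either core.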